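Tolerance on MT4 cells: an ester replaces a sulfonamide

A few compounds are considered here, and "the series" means these few. Any claim that something is new, unique, unknown or untested is made for them only; others in the source may bear on it.

The measured compounds and their values in a toxicity assay on MT4 cells (Homo sapiens) for cytotoxicity, read by MTT assay, with a stated time of 5 days (a lower number here means that less compound is tolerated, a higher number that more compound is tolerated), are:

Compound 1, `CC(=O)Nc1ccc(OCc2n[nH]c(=S)n2Cc2ccccc2)cc1`, gives 79 ug/mL.
Compound 2, `Cc1ccc(C(C)C)c(OCc2nnc(SCC(=O)Nc3ccc(S(N)(=O)=O)cc3)n2Cc2ccccc2)c1`, gives 13 ug/mL.
Compound 3, `CC(=O)Nc1ccc(OCc2nnc(SCC(=O)Nc3ccc(S(N)(=O)=O)cc3)n2Cc2ccccc2)cc1`, gives > 125 ug/mL, which is a limit of the assay and not a number.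

Compound 3 therefore stands at the limit of > 125 ug/mL in this assay, at which 1 of the 3 values shown sits. Of the measured steps, only one is known: an at least 9.6-fold higher number from compound 2 to compound 3 (0.98 log units; beyond the scatter). That step changes the group on the oxygen of the saturated carbon; it leaves the sulfamoylphenyl amide side of the molecule untouched.

Compound 4, `CCOC(=O)c1ccc(NC(=O)CSc2nnc(COc3ccc(NC(C)=O)cc3)n2Cc2ccccc2)cc1`, is not yet measured in this assay. The change from compound 3 is ethoxycarbonyl in place of sulfamoyl on an aromatic carbon. Within the data shown here, no measured step alters this end of the molecule, so the one known step, from compound 2 to compound 3, does not bear on it, and compound 1 offers no comparison on this side either. The size and direction of the change to compound 4 in this assay is therefore open. With compound 3 known only as a limit, compound 4 is expected to give 60 ug/mL, within 15 ug/mL to 125 ug/mL, an expectation that means an at least 2.0-fold lower number from compound 3 to compound 4 (0.31 log units; beyond the scatter).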

Compound 4, half-maximal cytotoxic concentration: 91.1 ug/mL
Estimate against measurement, compound 4: 1.5-fold (0.18 log units) below; the range from low to high includes it.
By their numbers in this assay, from the lowest: compound 2; then compounds 1 and 4 (each within the scatter of the next). At a limit, above all of these: compound 3.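

In this assay, this end of the molecule now has its first measured change: ethoxycarbonyl in place of sulfamoyl, on an aromatic carbon para to a large group, gives an at least 1.3-fold lower number from compound 3 to compound 4 (0.13 log units; that floor lies within the scatter). The floor of that step lies within the scatter, so the data do not establish that this exchange lowers the number at all, and the 4-acetamidophenyl series on the oxygen still tolerates a group other than sulfamoyl at this position with a measured value in the assay's range. The true size of the step stays unfixed because compound 3 is recorded only as a limit of the assay and not as a number: the limit of > 125 ug/mL in this assay, at which 1 of the 4 values shown sits.

The compounds shown leave open how a carboxylic acid, a primary amide or an ester with a longer chain than ethoxycarbonyl would read at this position in this assay. They also leave open whether the same exchange would give a comparable result with the 2-isopropyl-5-methylphenyl group of compound 2, which gives 13 ug/mL, in place of the 4-acetamidophenyl group on the oxygen.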